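The source may hold more compounds than are shown below. What is called first, only, known or untested is meant among the compounds shown, and "the series" means these compounds.

Compound 2 `c1coc(-c2ccccc2NCC2=NCCN2)c1` gives 0.468 nM in a functional assay for activation of Alpha-1A adrenergic receptor (Homo sapiens), read by calcium flux (on this read-out lower numbers stand for an effect already at smaller amounts and higher numbers for an effect only at larger amounts of compound), the lowest of the two numbers measured. Its nearest neighbour is compound 1 `c1ccc(-c2cnco2)c(NCC2=NCCN2)c1`, which in this assay gives 17.4 nM; the change a 37-fold lower number from compound 1 to compound 2 (1.57 log units; beyond the scatter) was large. Compound 3 `Cc1ncc(-c2ccccc2NCC2=NCCN2)o1` differs from compound 2 by 2-methyl-1,3-oxazol-5-yl in place of furan-2-yl on an aromatic carbon. This largely undoes the change that separated compound 1 from compound 2, so a step of similar size back towards higher numbers is expected, a 26-fold higher number from compound 2 to compound 3 (1.41 log units; beyond the scatter). For compound 3 the expected value in this assay is 12 nM, within a range from 2.5 nM to 60 nM.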

Compound 3, half-maximal effective concentration: 110 nM
For compound 3 the middle estimate is 9.2-fold (0.96 log units) below the measured one; the measured number lies above the stated range.
By their numbers in this assay, from the lowest: compound 2; then compound 1; then compound 3.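

Adding a methyl to the 1,3-oxazol-5-yl ring in this assay gives a 6.3-fold higher number from compound 1 to compound 3 (0.80 log units; beyond the scatter) and so moves the number further from that of compound 2, not back towards it. Replacing furan-2-yl gives a 240-fold higher number from compound 2 to compound 3 (2.37 log units; beyond the scatter) and is the largest step seen at this place on the aromatic carbon, so here the added methyl goes with a higher number, not a lower one. Nothing available explains either step. Still open, going by these compounds, is how an ethyl or an amine in place of this methyl would read, and whether a methyl on the furan-2-yl ring would raise the number too.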